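The source may report more compounds than this note shows. Statements on the series, on what has been measured and on what is new or still open speak of the compounds shown alone.

The three compounds share one core and differ only at one aromatic carbon of a six-membered aromatic ring of carbon only. Compound 1 `COc1ccc(NCC(=O)Oc2ccc3c(C)cc(=O)oc3c2)cc1` carries a methoxy group there, and in a functional assay on the whole organism (strain Wistar albino) for inhibition, with Rattus norvegicus as the target, read by paw edema, with stated times of 30 min and 2 h, at a dose of 20 mg/kg by the oral route (a lower number here means less inhibition, a higher number more inhibition at the dose given (going by the name of the read-out)), compound 1 gives 33.3%. Compound 2 `Cc1cc(=O)oc2cc(OC(=O)CNc3ccc(Cl)cc3)ccc12` has chloro in place of methoxy on an aromatic carbon, and in this assay compound 2 gives 23%. Going by the values given here, that exchange produced a number 10.3 percentage points lower from compound 1 to compound 2 (beyond the scatter), so compound 2 stands lowest of the two measured numbers, with compound 1 as its only neighbour, higher by a margin beyond the scatter.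

Compound 3 `Cc1cc(=O)oc2cc(OC(=O)CNc3ccc([N+](=O)[O-])cc3)ccc12` has not yet been measured. It differs from compound 2 in one place: nitro in place of chloro on an aromatic carbon. Among the compounds with values here, only one measured step concerns this same aromatic carbon, the change from methoxy to chloro, which moved this assay by a number 10.3 percentage points lower from compound 1 to compound 2 (beyond the scatter); no measured pair shows what nitro does at this position. With a single modest step to go by, and one involving different groups, the expected step in this assay is no change at the digits printed from compound 2 to compound 3 (within the scatter), not beyond the scatter. Compound 3 is therefore estimated at 23%, within a range from 10% to 36%.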

Compound 3, a percentage reported as inhibition, in the whole organism at one dose (the size of the read-out at that dose, not a potency): 17.9%
Estimate against measurement, compound 3: 5.1 percentage points above; the range from low to high includes it.
By their numbers in this assay, from the lowest: compounds 3 and 2 (each within the scatter of the next); then compound 1.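

In this assay, the result gives a number 5.1 percentage points lower from compound 2 to compound 3 (within the scatter), so nitro and chloro on this aromatic carbon cannot be told apart, even though nitro brings three heavy atoms and two hydrogen-bond acceptors where chloro has one heavy atom and none. The other new step gives a number 15.4 percentage points lower from compound 1 to compound 3 (beyond the scatter), which shows that a second replacement of methoxy at this carbon also ends in a lower number, and among these three compounds methoxy alone stands apart from the other two groups. No measurement offered here bears on why these numbers fall as they do.

The compounds shown leave open whether methoxy is unusual at this carbon or whether other groups would match or pass it: an amine, a hydroxyl group, a carboxylic acid or a longer ether chain such as ethoxy in the same place would help to settle that. They also leave open whether the separation between methoxy and the other two groups would persist at other doses, as each number here is a read-out at a single dose and not a potency.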